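The source may report more compounds than this note shows. Statements on the series, on what has been measured and on what is new or still open speak of the compounds shown alone.

- Compound 1 `Cc1ccc(C(=O)Nc2cccc(C(F)(F)F)c2)cc1-c1ccc2c(-c3ccc(N4CCN(C)CC4)cc3)n[nH]c2c1`: 136 nM
- Compound 2 `Cc1ccc(C(=O)Nc2cccc(C(F)(F)F)c2)cc1-c1ccc2c(-c3ccc(C(=O)N4CCN(C)CC4)cc3)n[nH]c2c1`: 300 nM

Going by the values given here, in a functional assay on KG-1 cells (Homo sapiens) for antiproliferative activity, read by CCK-8 assay, with a stated time of 72 h (a lower number here means a stronger inhibitor, a higher number a weaker inhibitor), compound 2 gives 300 nM, the higher of the two numbers measured so far, which makes it the weaker inhibitor of the pair. Compound 3 `Cc1ccc(C(=O)Nc2cccc(C(F)(F)F)c2)cc1-c1ccc2c(-c3ccc(CN4CCN(C)CC4)cc3)n[nH]c2c1` differs from compound 2 in one place: (4-methylpiperazin-1-yl)methyl in place of (4-methylpiperazin-1-yl)carbonyl on an aromatic carbon. The change lies on an aromatic carbon of a six-membered aromatic ring of carbon only, para to a large group, and it removes the carbonyl.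

Among the compounds with values here, only one measured step bears on this change: a 2.2-fold higher number from compound 1 to compound 2 (0.34 log units; beyond the scatter). That modest step came with (4-methylpiperazin-1-yl)carbonyl taking the place of 4-methylpiperazin-1-yl at the same position. Within the data shown here, no measurement yet covers the (4-methylpiperazin-1-yl)methyl group itself. Compound 3 shares the absence of that carbonyl with compound 1, which gives 136 nM, so a modest move towards a lower number in this assay is expected, of about the same size as the measured step. The expected step is a 2.1-fold lower number from compound 2 to compound 3 (0.33 log units; beyond the scatter). Compound 3 is estimated at 140 nM, with an expected range of 45 nM to 420 nM.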

Compound 3, half-maximal inhibitory concentration: 120 nM
Beside the measured number, compound 3's estimate is 1.2-fold (0.07 log units) above it, and the stated range covers the measured number.
By their numbers in this assay, from the lowest: compounds 3 and 1 (each within the scatter of the next); then compound 2.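

The carbonyl proves to be the part of the group that matters in this set: in this assay, replacing (4-methylpiperazin-1-yl)carbonyl with (4-methylpiperazin-1-yl)methyl on the same aromatic carbon gives a 2.5-fold lower number from compound 2 to compound 3 (0.40 log units; beyond the scatter). The earlier pair could not separate the presence of the carbonyl from the mere presence of an extra atom joining the piperazine ring to the aromatic carbon, but the step of a 1.1-fold lower number from compound 1 to compound 3 (0.05 log units; within the scatter) now shows that the methyl-linked and directly attached groups cannot be told apart in this assay, leaving compound 2 as the only one of the three set apart by a step beyond the scatter. Nothing available explains why the carbonyl goes with the higher number, so this remains an observed link across three compounds and no more.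

As far as these compounds go, how a longer chain, such as an ethyl link to the same 4-methylpiperazine, or a morpholine ring in place of the piperazine would read in this assay remains open. The compounds shown also leave open whether the same carbonyl-to-methyl change would give a similar step with a different amine or on a different core.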